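The source may hold more compounds than are shown below. What is called first, only, known or untested is meant among the compounds shown, and "the series" means these compounds.

Measured in a functional assay on A-431 cells (Homo sapiens), read by propidium iodide staining, with a stated time of 24 h; a lower number here means that less compound is needed, a higher number that more compound is needed for the effect:
- Compound 1 `c1cncc(CNc2ncccc2-c2nnc(Nc3ccc4c(c3)OCCO4)o2)c1`: 13 nM
- Compound 2 `c1cnc(NCc2ccc3ncccc3c2)c(-c2nnc(Nc3ccc4c(c3)OCCO4)o2)c1`: 18 nM
- Compound 3 `c1cncc(CNc2ccccc2-c2nnc(Nc3ccc4c(c3)OCCO4)[nH]2)c1`: > 10000 nM, a limit and not a number

Compound 3 sits at the limit of > 10000 nM in this assay, at which 1 of the 3 values shown sits. Compound 4 `c1ccc(-c2nnc(Nc3ccc4c(c3)OCCO4)[nH]2)c(NCc2ccc3ncccc3c2)c1` is not yet measured, and it differs from compound 3 in one place: quinolin-6-yl in place of pyridin-3-yl on a saturated chain carbon bound to a nitrogen on an aromatic ring. In words, quinolin-6-yl stands in place of pyridin-3-yl on a saturated chain carbon bound to a nitrogen on an aromatic ring.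

The same swap has been measured once, on a different core, and that single case shows a 1.4-fold higher number from compound 1 to compound 2 (0.14 log units; within the scatter). This is thin evidence, and it comes from a pair with real numbers rather than a limit. Even so, with a 1.4-fold higher number from compound 1 to compound 2 (0.14 log units; within the scatter) as the only guide, no step beyond the scatter is expected in this assay, in either direction. The most likely report is therefore the limit again. The estimated step is a number no higher from compound 3 to compound 4 (the limit leaves the size open). Compound 4 is expected at about 10000 nM, with an estimated range of 3000 nM to 20000 nM.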

Compound 4, half-maximal effective concentration: > 10000 nM
Compound 4: only a limit was reported; the forecaster's own chance of this, stated with the estimate: 80%; the middle value sits exactly at the limit.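

Compound 3 and compound 4 are each reported only as a limit, so no step between them can be read in this assay: the limit of > 10000 nM in this assay, at which 2 of the 4 values shown sit.

The compounds shown leave open whether quinolin-6-yl in place of pyridin-3-yl changes the number at all on the core of compound 3.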